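From Methoxycarbonyl to Phenoxy: Expecting Compound 3

The compounds below may be only part of what the source reports. "The series", "measured", "known", "first", "only" and "open" are said of these compounds alone.

Measured compounds:
Compound 1, `C[C@H]1[C@H](NC(=O)OCCCCC2CCCCC2)C(=O)N1Oc1ccc([N+](=O)[O-])cc1`, gives 17 nM in an assay on HEK293 cells for inhibition of N-acylethanolamine-hydrolyzing acid amidase (Homo sapiens), read by fluorescence, with stated times of 10 min and 50 min; a higher number here means a weaker inhibitor, a lower number a stronger inhibitor.
Compound 2, `COC(=O)c1ccc(ON2C(=O)[C@@H](NC(=O)OCCCCC3CCCCC3)[C@@H]2C)cc1`, gives 17 nM in this assay.

Compound 2 stands level with compound 1 in this assay. Among the compounds with values here, the one measured step, no change at the digits printed from compound 1 to compound 2 (within the scatter), shows that exchanging nitro for methoxycarbonyl on the aromatic carbon leaves the half-maximal inhibitory concentration where it was, within the scatter.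

Compound 3, `C[C@H]1[C@H](NC(=O)OCCCCC2CCCCC2)C(=O)N1Oc1ccc(Oc2ccccc2)cc1`, has not yet been measured. It differs from compound 2 in one place: phenoxy in place of methoxycarbonyl on an aromatic carbon. Within the data shown here, the only step that bears on this change is no change at the digits printed from compound 1 to compound 2 (within the scatter), and that step exchanged two small groups on the same aromatic carbon. Phenoxy is a larger replacement and brings in a six-membered aromatic ring of carbon only, so the measured step gives only limited guidance. Because the neighbouring exchange no change at the digits printed from compound 1 to compound 2 (within the scatter) produced no change, the expected step is a 1.5-fold higher number from compound 2 to compound 3 (0.17 log units; within the scatter), with a wider range to allow for the larger structural change. Compound 3 is therefore estimated at 25 nM, between 7 nM and 90 nM.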

Compound 3, half-maximal inhibitory concentration: 48 nM
Beside the measured number, compound 3's estimate is 1.9-fold (0.28 log units) below it; the range from low to high includes it.
By their numbers in this assay, from the lowest: compounds 1 and 2 (each within the scatter of the next); then compound 3.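

Within the data shown here, compound 1 and compound 2 could not show whether the group on this aromatic carbon matters at all in this assay, but phenoxy brings the first change here that lies beyond the scatter, with a 2.8-fold higher number from compound 2 to compound 3 (0.45 log units; beyond the scatter) and a 2.8-fold higher number from compound 1 to compound 3 (0.45 log units; beyond the scatter). The position therefore responds to what is placed on it, at least when the incoming group carries a six-membered aromatic ring of carbon only, yet the response is modest and compound 3 still gives 48 nM. Nothing measured here explains this step, so the compounds give no reason why phenoxy reads differently from the two smaller groups.

The three compounds cannot separate the contribution of the added ring from that of the oxygen linking it, so a plain phenyl group or a small methoxy group on the same carbon would be informative. Going by these compounds, it also remains open how this position would respond to a group of a different kind, such as a dimethylamino group or a carboxylic acid, and whether a still larger group such as benzyloxy would move the number further.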